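Three Inactive Analogues and a Fourth Sharing Their Core

This account rests on a few compounds, and the source may have more. Where it says the series, first, only, none or still open, it means among the compounds named here.

Compound 1 `O=C1O/C(=C\Cn2cc(-c3cc(F)cc(F)c3)nn2)C(OCc2ccccc2)=C1OCc1ccccc1`: in a functional assay on SW-620 cells (Homo sapiens) for antiproliferative activity, read by MTT assay, with a stated time of 72 h (a higher number here means a weaker inhibitor, a lower number a stronger inhibitor), compound 1 gives > 100000 nM, a limit of the assay.
Compound 2 `COc1ccccc1-c1cn(C[C@H](O)[C@H]2OC(=O)C(OCc3ccccc3)=C2OCc2ccccc2)nn1`: compound 2 gives > 100000 nM, also a limit.
Compound 3 `O=C1O/C(=C\Cn2cc(-c3cc(C(F)(F)F)cc(C(F)(F)F)c3)nn2)C(OCc2ccccc2)=C1OCc1ccccc1`: compound 3 gives > 100000 nM, again a limit.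

Compound 2 therefore stands at the limit of > 100000 nM in this assay, at which 3 of the 3 values shown sit, so no number places it relative to the others. Compound 4 `O=C1O[C@H]([C@@H](O)Cn2cc(-c3cc(F)cc(F)c3)nn2)C(OCc2ccccc2)=C1OCc1ccccc1` carries 3,5-difluorophenyl in place of 2-methoxyphenyl on an aromatic carbon. Among the compounds with values here, no step between measured compounds is available, and compound 1, which bears the same 3,5-difluorophenyl group, sits at the same limit. The step from compound 2 to compound 4 is expected to be none beyond the scatter, a step that the limit leaves unreadable from compound 2 to compound 4. Compound 4 is expected to give 150000 nM, between 50000 nM and 500000 nM, most likely again as a limit.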

Compound 4, half-maximal inhibitory concentration: > 100000 nM
Compound 4: only a limit was reported (the forecaster's own chance of this, stated with the estimate: 85%); the middle value lies beyond the limit too.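

In this assay compound 4 gives > 100000 nM, a limit of the assay. Like compound 2, it yields no readable step between the two compounds. The compounds shown leave open whether any of them truly differs from another in this assay.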